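The source may hold more compounds than are shown below. What is called first, only, known or untested is meant among the compounds shown, and "the series" means these compounds.

Going by the values given here, compound 1 `Cc1ccc(NC2=CC(=O)c3nc4n(c3C2=O)[C@H]2OC[C@@H](O)[C@H]2OC4)cc1` is the one member of this small set with a real number behind it: in a functional assay on MCF7 cells (Homo sapiens) for inhibition, read by sulforhodamine B assay (a lower number here means a stronger inhibitor, a higher number a weaker inhibitor), compound 1 gives 1660 nM. The two other measured compounds are known only as limits of the assay, not as numbers. Compound 2 `CCOc1ccc(NC2=CC(=O)c3c(nc4n3[C@H]3OC[C@@H](O)[C@H]3OC4)C2=O)cc1` is reported in this assay as a limit, > 4000 nM. Compound 3 `O=C1C(Nc2ccccc2F)=CC(=O)c2c1nc1n2[C@H]2OC[C@@H](O)[C@H]2OC1` is likewise reported in this assay only as a limit, > 4000 nM. Among the compounds with values here, the one measured step between neighbours, a step that the two limits leave unreadable from compound 2 to compound 3, therefore cannot be sized at all. What the two limits do show is that both sit at the same point: the limit of > 4000 nM in this assay, at which 2 of the 3 values shown sit.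

Compound 4 `CCOc1ccccc1NC1=CC(=O)c2nc3n(c2C1=O)[C@H]1OC[C@@H](O)[C@H]1OC3` has not yet been measured. It differs from compound 1 in one place: 2-ethoxyphenyl in place of 4-methylphenyl on an amine nitrogen. Within the data shown here, no measured step mirrors this change directly. Among the measured compounds shown here, still, the only compound carrying an ethoxyphenyl group on that nitrogen, compound 2, reached only a limit, and compound 3, which carries 2-fluorophenyl on the same nitrogen, also reached only a limit. The change is therefore expected to weaken inhibition, and the expected step is a 2.7-fold higher number from compound 1 to compound 4 (0.43 log units; beyond the scatter). Compound 4 is estimated at 4500 nM, within 1500 nM to 12000 nM, and it may well come back only as a limit.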

Compound 4, half-maximal inhibitory concentration: > 4000 nM
Compound 4: no number, only a limit; the forecaster's own chance of this, stated with the estimate: 55%; the middle value lies beyond the limit too.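

Going by these compounds alone, on the amine nitrogen of the shared core, 2-ethoxyphenyl in place of 4-methylphenyl gives an at least 2.4-fold higher number from compound 1 to compound 4 (0.38 log units; beyond the scatter) in this assay and is the first step in this set that can be read. From the compounds shown here alone, until now, nothing showed that a swap at this place could move the value away from that of compound 1; this one weakens inhibition beyond the usual scatter, although compound 4 is known only as a limit and the full size of the step remains unknown. Compound 1 is now the lone exception among the four aryl-bearing compounds, with its 4-methylphenyl group, as all the others end at the same point: the limit of > 4000 nM in this assay, at which 3 of the 4 values shown sit.

Compounds 2 and 4 are both reported only as limits, so the compounds shown cannot tell whether moving the ethoxy group around the phenyl ring changes inhibition. They also leave open whether any other group on this nitrogen, such as a phenyl ring carrying an amine or a carboxylic acid, or a longer chain in place of the ring, would match or improve on compound 1.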